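The source may report more compounds than this note shows. Statements on the series, on what has been measured and on what is new or still open speak of the compounds shown alone.

Compound 1 `CCSC(=S)N[C@H]1CCOC1=O` is the starting point of the set. In a functional assay on SMMC-7721 cells (Homo sapiens) for cytotoxicity, read by MTT assay, with a stated time of 72 h (a higher number here means a weaker inhibitor, a lower number a stronger inhibitor), compound 1 reaches only the limit of the assay, > 128000 nM. Compound 2 `CCCCSC(=S)N[C@H]1CCOC1=O` differs from compound 1 by ethyl in place of hydrogen on a saturated chain carbon, two bonds along the chain from a sulfur. In this assay compound 2 likewise sits at the limit, > 128000 nM. The step that the two limits leave unreadable from compound 1 to compound 2 thus has no readable size, because the limit of > 128000 nM in this assay, at which 2 of the 3 values shown sit, holds both ends of it. Compound 3 `CCCCCCCCCCCCSC(=S)N[C@H]1CCOC1=O` stands apart from compound 1 by more than one change; the difference between the core of compound 3 and the core of compound 1 is not broken down here. In this assay, going by the values given here, compound 3 gives 50300 nM, the one value in the set that is a number rather than a limit.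

Compound 4 `CCCCCCCCCCCCCCSC(=S)N[C@H]1CCOC1=O` is not yet measured. It differs from compound 3 by ethyl in place of hydrogen on a saturated chain carbon, ten or more bonds along the chain from a sulfur. Among the compounds with values here, this is the same kind of change as the one from compound 1 to compound 2, but not the same change: the ethyl enters at a different place along the chain, as the computed differences show. The earlier step offers no yardstick, since its size could not be read. What the set does show is that compound 3, with the longer chain, gives the number 50300 nM. Compound 1 and compound 2 give a limit only. On that basis compound 4 is expected to move by about a 1.6-fold lower number from compound 3 to compound 4 (0.20 log units; within the scatter) from compound 3, a small step at most. The estimate for compound 4 is 32000 nM, expected to lie between 10000 nM and 90000 nM.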

Compound 4, half-maximal inhibitory concentration: 56800 nM
Beside the measured number, compound 4's estimate is 1.8-fold (0.25 log units) below it, and the stated range covers the measured number.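

In this assay ethyl in place of hydrogen on a saturated chain carbon, ten or more bonds along the chain from a sulfur, gives a 1.1-fold higher number from compound 3 to compound 4 (0.05 log units; within the scatter) and so this single readable instance of the change shows no difference that stands out from the scatter. That result holds only for this place on this long chain: it gives no size for the change on any other core and no rule that the same ethyl would be without consequence elsewhere in the series. The same kind of change, two bonds along the chain from a sulfur, cannot be read on the core of compound 1, and the two steps cannot be compared, with both ends of the earlier step held at a limit: the limit of > 128000 nM in this assay, at which 2 of the 4 values shown sit.

Still open, going by these compounds, is what a chain carrying an amine or a carboxylic acid would give on the shared core in this assay, and whether either would stand apart from the scatter around the values of the long chains. Also open, on these data alone, is what a longer chain than that of compound 4, or a phenyl group in place of the chain, would give in the same read-out.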